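A few compounds are considered here, and "the series" means these few. Any claim that something is new, unique, unknown or untested is made for them only; others in the source may bear on it.

Measured in a functional assay on CNE-2 cells (Homo sapiens) for antiproliferative activity, read by sulforhodamine B assay, with a stated time of 48 h; on this read-out lower numbers stand for stronger inhibition and higher numbers for weaker inhibition:
- compound 1 `COc1ccc(-c2ccccc2C(=O)/C=C/c2ccc(F)cc2)cc1OC`: 5400 nM
- compound 2 `COc1ccc(-c2ccccc2C(=O)/C=C/c2ccc(Br)cc2)cc1OC`: 4800 nM
- compound 3 `COc1ccc(/C=C/C(=O)c2ccccc2-c2ccc(F)cc2)cc1`: 53 nM

Among these three, compound 3 has the lowest number, 53 nM, and it lies well beyond the usual scatter from both of the others. That makes it the strongest inhibitor so far in this assay.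

Compound 4 `COc1ccc(/C=C/C(=O)c2ccccc2-c2ccc(F)cc2)cc1O` is compound 3 with one change: hydroxy in place of hydrogen on an aromatic carbon. Here hydroxy takes the place of hydrogen on an aromatic carbon, ortho to a methoxy group.

For the measured compounds named here, only one measured step compares neighbours that differ in a single place: a 1.1-fold lower number from compound 1 to compound 2 (0.05 log units; within the scatter), with bromo in place of fluoro on an aromatic carbon. That step lies within the scatter, but it involves a different exchange, so it offers little guidance here. Going by the values given here, no measured step adds a hydroxy, so the expectation stays close to compound 3 and carries wide uncertainty.

The expected step, no larger than the scatter, is a 1.1-fold higher number from compound 3 to compound 4 (0.05 log units; within the scatter). For compound 4 the estimate is 60 nM, with an expected range from 15 nM to 300 nM.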

Compound 4, half-maximal inhibitory concentration: 87 nM
The estimate for compound 4 lay 1.5-fold (0.16 log units) below the measured number; the measured number falls inside the stated range.
By their numbers in this assay, from the lowest: compounds 3 and 4 (each within the scatter of the next); then compounds 2 and 1 (each within the scatter of the next).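

In this assay, placing a hydroxy ortho to a methoxy group gives a 1.6-fold higher number from compound 3 to compound 4 (0.22 log units; within the scatter) and so makes no clear difference to the result. For the compounds shown here, the only earlier single-place step exchanged fluoro for bromo on an aromatic carbon, so this is the first sign that a new group can enter on the methoxy-bearing ring without moving the number beyond the usual scatter. Compound 4 therefore remains level with compound 3, and this position can carry a hydroxy without losing the strong inhibition seen there.

As far as these compounds go, it remains open whether an amine, a carboxylic acid or a longer chain at this same position would also stay level with compound 3, or whether any of them would shift the number clearly. No measurement at hand offers an explanation for this result.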